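The source may report more compounds than this note shows. Statements on the series, on what has been measured and on what is new or still open speak of the compounds shown alone.

In a functional assay on MCF7 cells (Homo sapiens) for cytotoxicity, tested at 125 uM (on this read-out lower numbers stand for a stronger effect and higher numbers for a weaker effect at the one concentration tested), compound 1 `COc1ccc(S(=O)(=O)Nc2nnc(SCc3ccccc3)s2)cc1` gives 76%, while compound 2 `COc1ccc(S(=O)(=O)Nc2nnc(SCc3ccc(Cl)cc3)s2)cc1` gives 55%. For the measured compounds named here, the single measured step, a number 21 percentage points lower from compound 1 to compound 2 (beyond the scatter), came from chloro in place of hydrogen on an aromatic carbon, and compound 2 therefore stands lowest of the two numbers. Compound 3 `Cc1cc(C)c(S(=O)(=O)Nc2nnc(SCc3ccc(Cl)cc3)s2)c(C)c1` differs from compound 2 by 2,4,6-trimethylphenyl in place of 4-methoxyphenyl on a sulfonyl sulfur. Going by the values given here, no measured step touches this part of the molecule, so nothing shows how the number responds to such a change there. The expected step is accordingly no change at the digits printed from compound 2 to compound 3 (within the scatter), not beyond the scatter. Compound 3 is expected to give 55%, somewhere between 35% and 80%.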

Compound 3, a percentage reported as activity, at one concentration (the size of the read-out at that concentration, not a potency): 82%
Compound 3: the middle estimate sits 27 percentage points below what was measured; the whole stated range lies below it.
By their numbers in this assay, from the lowest: compound 2; then compounds 1 and 3 (each within the scatter of the next).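

The group on the sulfonyl sulfur is not a silent position: in this assay, 2,4,6-trimethylphenyl in place of 4-methoxyphenyl gives a number 27 percentage points higher from compound 2 to compound 3 (beyond the scatter), which means a weaker effect at the one concentration tested. The number therefore responds to a change at this place as well as to the chloro step. Nothing available explains why this swap weakens the effect.

Still open, going by these compounds, is how a plain phenyl or an aminophenyl group would behave at this position. Also open, on these data alone, is whether the same swap would shift the number similarly without the chloro.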